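Aryl amide exchange on compound 1: outlook for compound 4

A few compounds are considered here, and "the series" means these few. Any claim that something is new, unique, unknown or untested is made for them only; others in the source may bear on it.

Compound 1 `Cc1ccc(S(=O)(=O)NCc2ccc(CNC(=O)c3ccccc3Cl)cc2)cc1` is the reference point of this set. In an assay on MDA-MB-231 cells for binding affinity to C-X-C chemokine receptor type 4 (Homo sapiens), read by immunofluorescence and microscopy, with stated times of 10 min and 30 min (on this read-out higher numbers stand for an effect only at larger amounts of compound and lower numbers for an effect already at smaller amounts), compound 1 gives 10 nM. Compound 2 `O=C(NCc1ccc(CNS(=O)(=O)c2ccccc2)cc1)c1ccccc1Cl` gives 10 nM in the same assay, and the step of no change at the digits printed from compound 1 to compound 2 (within the scatter) shows that the methyl on the sulfonyl-bearing ring makes no difference here. Compound 3 `COc1cccc(C(=O)NCc2ccc(CNS(=O)(=O)c3ccccc3)cc2)c1` reaches only a limit of the assay, > 1000 nM. Within the data shown here, the step of an at least 100-fold higher number from compound 2 to compound 3 (2.00 log units; beyond the scatter) is the one measured change at the aryl on the carbonyl carbon, and its size rests on (the limit of > 1000 nM in this assay, at which 1 of the 3 values shown sits).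

Compound 4 `Cc1ccc(C(=O)NCc2ccc(CNS(=O)(=O)c3ccc(C)cc3)cc2)cc1` differs from compound 1 in exactly that position: 4-methylphenyl in place of 2-chlorophenyl on a carbonyl carbon. Among the measured compounds shown here, the only measured step that bears on this place is the one from compound 2 to compound 3, which was large and unfavourable; no measured pair tells how 4-methylphenyl in particular behaves, so its size cannot be transferred directly. For the measured compounds named here, compound 4 is therefore expected to lose ground against compound 1, with the step of a 30-fold higher number from compound 1 to compound 4 (1.48 log units; beyond the scatter) estimated as smaller than the one seen for compound 3 but clearly beyond the scatter. The estimate for compound 4 in this assay is 300 nM, within a range from 30 nM to 3000 nM.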

Compound 4, effective concentration (reported as EC, without a stated level of effect): 1000 nM
Compound 4: the middle estimate sits 3.3-fold (0.52 log units) below what was measured; measured number inside the range.
By their numbers in this assay, from the lowest: compounds 1 and 2 (each within the scatter of the next); then compound 4.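

In this assay, putting 4-methylphenyl in place of 2-chlorophenyl on the carbonyl carbon gives a 100-fold higher number from compound 1 to compound 4 (2.00 log units; beyond the scatter), so the loss at this position now has a step with a number at both ends. The group that enters matches the one that leaves in heavy-atom count, in its single six-membered aromatic ring of carbon only and in having no hydrogen-bond donors or acceptors, so these counts do not tell the low values from the high one; among the compounds shown, only compound 1 and compound 2 carry 2-chlorophenyl here and only they keep the low number, and none goes against this. Compound 3 remains a limit, so the size of the earlier step at this position stays open and cannot be set against the new one: the limit of > 1000 nM in this assay, at which 1 of the 4 values shown sits.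

Still open, going by these compounds, is whether the loss follows the chlorine itself or where the substituent sits on the ring, a question that 2-methylphenyl and 4-chlorophenyl on this carbonyl carbon would separate. Also open, on these data alone, is how an amine, a carboxylic acid or a longer chain would behave at this place on the core of compound 1.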